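Amino in place of bromo on the benzylic carbon

The source may report more compounds than this note shows. Statements on the series, on what has been measured and on what is new or still open speak of the compounds shown alone.

Measured compounds:
compound 1, `O=C(NCc1cc(C(F)(F)F)cc(C(F)(F)F)c1)c1c(CCl)nc2ccccc2c1-c1ccccc1` — 26 nM
compound 2, `O=C(NCc1cc(C(F)(F)F)cc(C(F)(F)F)c1)c1c(CBr)nc2ccccc2c1-c1ccccc1` — 0.01 nM

Compound 2 gives the lowest number of the two in an in vitro assay on UC11MG cells for binding affinity to Substance-P receptor (Homo sapiens), read by radioligand binding (on this read-out higher numbers stand for weaker inhibition and lower numbers for stronger inhibition), and its nearest neighbour on that read-out is compound 1, which gives 26 nM. The one step shown between the two, a 2600-fold lower number from compound 1 to compound 2 (3.41 log units; beyond the scatter), is large and well beyond the scatter.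

Compound 3, `NCc1nc2ccccc2c(-c2ccccc2)c1C(=O)NCc1cc(C(F)(F)F)cc(C(F)(F)F)c1`, has not yet been measured. It differs from compound 2 by amino in place of bromo on a saturated chain carbon bound to an aromatic carbon. No measured step exchanges bromo for amino at this position, so the one step shown bears only indirectly: it shows that a single-atom exchange on this saturated chain carbon can move the number a great deal. Compound 3 is therefore expected to give a number that lies well above compound 2, though the direction and size are uncertain, and the estimate a 300-fold higher number from compound 2 to compound 3 (2.48 log units; beyond the scatter) carries a wide range. The expected value for compound 3 in this assay is 3 nM, within the range 0.05 nM to 150 nM.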

Compound 3, half-maximal inhibitory concentration: 0.0017 nM
For compound 3 the middle estimate is 1800-fold (3.25 log units) above the measured one; the measured number lies below the stated range.
By their numbers in this assay, from the lowest: compound 3; then compound 2; then compound 1.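

Amino in place of bromo on the saturated chain carbon bound to an aromatic carbon gives a 5.9-fold lower number from compound 2 to compound 3 (0.77 log units; beyond the scatter) in this assay. A low number at this position is therefore not tied to a halogen: compound 3, the only one of the three without a halogen on this carbon, gives the lowest number, and its steps to both others lie beyond the scatter. Set against the chloro group, the same exchange gives a 15000-fold lower number from compound 1 to compound 3 (4.18 log units; beyond the scatter), so the three groups on this one carbon span a very wide range while the rest of the molecule stays the same. No evidence on why these groups differ so strongly is at hand.

The compounds shown leave open whether a substituted amine such as methylamino or dimethylamino, a hydroxyl group, or a longer chain such as aminoethyl would keep a number as low as that of compound 3 on this carbon. They also leave open whether the aminomethyl group would have the same effect if the phenyl group or the bis(trifluoromethyl)benzyl amide on the shared core were replaced by other groups.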